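This account rests on a few compounds, and the source may have more. Where it says the series, first, only, none or still open, it means among the compounds named here.

In a functional assay on U-87MG ATCC cells for antiproliferative activity against U-87 MG (Homo sapiens), read by MTT assay, with a stated time of 72 h (a lower number here means a stronger inhibitor, a higher number a weaker inhibitor), the two measured compounds read as follows:

compound 1 `O=C(Nc1ccc(Oc2ccnc3[nH]ccc23)cc1)c1cc2cccnc2n(-c2ccccc2)c1=O`, with 1580 nM;
compound 2 `O=C(Nc1ccc(Oc2ccnc3[nH]ccc23)cc1)c1cc2cccnc2n(-c2ccc(F)cc2)c1=O`, with 1360 nM.

Compound 2 gives the lower of the two numbers, but the gap to compound 1 is within the scatter, as the step of a 1.2-fold lower number from compound 1 to compound 2 (0.07 log units; within the scatter) shows. Compound 3 `O=C(Nc1ccc(Oc2ccnc3[nH]ccc23)cc1)c1cc2cccnc2n(-c2ccc(Cl)cc2)c1=O` differs from compound 2 by chloro in place of fluoro on an aromatic carbon. Among the compounds with values here, only that one measured step bears on the change, and it was small, so compound 3 is expected to land close to compound 2, with a step of a 1.2-fold lower number from compound 2 to compound 3 (0.09 log units; within the scatter). The estimate for compound 3 is 1100 nM, within a range from 500 nM to 2500 nM.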

Compound 3, half-maximal inhibitory concentration: 3370 nM
Compound 3: middle estimate off by 3.1-fold (0.49 log units), on the low side, outside the stated range (above it).
By their numbers in this assay, from the lowest: compounds 2 and 1 (each within the scatter of the next); then compound 3.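

At this place on the aromatic ring, para to a large group, the substituent does matter: in this assay the change from 4-fluorophenyl to 4-chlorophenyl gives a 2.5-fold higher number from compound 2 to compound 3 (0.39 log units; beyond the scatter). Chloro in place of hydrogen gives a 2.1-fold higher number from compound 1 to compound 3 (0.33 log units; beyond the scatter), so of the two halogens only chloro moves the number beyond the scatter. Nothing available explains this difference between the two halogens.

The compounds shown leave open whether bromo would follow chloro here. On these data alone, it is also open how a methoxy group or an amine at this place would read.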